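Adding a nitro group to the phenyl of compound 2

A few compounds are considered here, and "the series" means these few. Any claim that something is new, unique, unknown or untested is made for them only; others in the source may bear on it.

Compound 1, `Cc1nn(C)c2c(O)nc(-c3ccncc3)nc12`, gives 950 nM in an assay on membranes from brain for binding affinity to adenosine receptor A1 (Rattus norvegicus), read by radioligand binding; on this read-out higher numbers stand for weaker inhibition and lower numbers for stronger inhibition.
Compound 2, `Cc1nn(C)c2c(O)nc(-c3ccccc3)nc12`, gives 1020 nM in this assay.

Among the measured compounds shown here, compound 2 sits within the usual scatter of compound 1, as the single measured step, a 1.1-fold higher number from compound 1 to compound 2 (0.03 log units; within the scatter), shows. Compound 3, `Cc1nn(C)c2c(O)nc(-c3cccc([N+](=O)[O-])c3)nc12`, differs from compound 2 by nitro in place of hydrogen on an aromatic carbon. For the measured compounds named here, no measured step adds a nitro group, and the only step available exchanged one aromatic ring for another without moving the number beyond the scatter, so it gives little guidance. Compound 3 is therefore expected to stay close, a 1.0-fold lower number from compound 2 to compound 3 (0.01 log units; within the scatter). The estimate for compound 3 is 1000 nM, with a range from 400 nM to 2500 nM.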

Compound 3, half-maximal inhibitory concentration: 1200 nM
Estimate against measurement, compound 3: 1.2-fold (0.08 log units) below; low and high end bracket the measured number.
By their numbers in this assay, from the lowest: compounds 1, 2 and 3 (each within the scatter of the next).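

Placing a nitro group on the phenyl ring, meta to a large group, adds three heavy atoms, yet the step of a 1.2-fold higher number from compound 2 to compound 3 (0.07 log units; within the scatter) in this assay stays within the scatter. This position can therefore carry a nitro group in place of hydrogen without a readable shift in the number, which the earlier exchange of one ring for another could not show. Nothing measured here explains why the number holds. From the compounds shown here alone, whether an amine or a carboxylic acid in the same place would also leave the number unchanged remains open, as does the effect of a nitro group on another carbon of the phenyl ring.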